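The source may hold more compounds than are shown below. What is called first, only, known or untested is meant among the compounds shown, and "the series" means these compounds.

In a functional assay on A549 cells (Homo sapiens) for inhibition, read by MTT assay, with a stated time of 72 h (on this read-out lower numbers stand for stronger inhibition and higher numbers for weaker inhibition), three compounds have been measured:

Compound 1 `CCCc1ccc(NC(=O)C2CCN(C/C=C/c3ccccc3)CC2)cc1`: 9470 nM
Compound 2 `CC(C)c1ccc(NC(=O)C2CCN(C/C=C/c3ccccc3)CC2)cc1`: 9430 nM
Compound 3 `CCCCCc1ccc(NC(=O)C2CCN(C/C=C/c3ccccc3)CC2)cc1`: 3880 nM

Compound 3 has the lowest number of the three, and both other compounds lie beyond the scatter from it. The next compound, compound 4 `COc1ccc(NC(=O)C2CCN(C/C=C/c3ccccc3)CC2)cc1`, has methoxy in place of pentyl on an aromatic carbon, para to a large group: methoxy in place of pentyl on an aromatic carbon.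

Among the compounds with values here, three measured steps bear on this change. Exchanging propyl for isopropyl gave a 1.0-fold lower number from compound 1 to compound 2 (0.00 log units; within the scatter). The two steps that end at the pentyl compound are modest: a 2.4-fold lower number from compound 1 to compound 3 (0.39 log units; beyond the scatter) and a 2.4-fold lower number from compound 2 to compound 3 (0.39 log units; beyond the scatter). Within the data shown here, no measured compound carries methoxy, so these steps offer only an indirect guide. Losing pentyl is expected to reverse a step of about that size in this assay, perhaps a little more, towards a higher number.

The expected change is a 3.1-fold higher number from compound 3 to compound 4 (0.49 log units; beyond the scatter). For compound 4 the estimated value is 12000 nM, with an expected range from 6000 nM to 30000 nM.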

Compound 4, half-maximal inhibitory concentration: 83800 nM
Estimate against measurement, compound 4: 7.0-fold (0.84 log units) below; the whole stated range lies below it.
By their numbers in this assay, from the lowest: compound 3; then compounds 2 and 1 (each within the scatter of the next); then compound 4.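

In this assay, within the data shown here, this position on the aromatic ring, para to a large group, proves far more sensitive than the earlier compounds suggested: replacing pentyl with methoxy gives a 22-fold higher number from compound 3 to compound 4 (1.33 log units; beyond the scatter). The change also separates methoxy from the shorter chains, with an 8.9-fold higher number from compound 2 to compound 4 (0.95 log units; beyond the scatter) and an 8.8-fold higher number from compound 1 to compound 4 (0.95 log units; beyond the scatter), so compound 4 has the highest number of the four, although propyl and isopropyl had shown no difference beyond the scatter. No measurement here accounts for the size of these steps.

The compounds shown leave open whether the rise follows the oxygen of methoxy or the smaller group, a question that a pentyloxy chain set against pentyl, or an ethyl group set against methoxy, could address. On these data alone, it also remains open whether a chain longer than pentyl would lower the number further.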